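Adding a methyl to the core of compound 1

The source may report more compounds than this note shows. Statements on the series, on what has been measured and on what is new or still open speak of the compounds shown alone.

Compound 1 `CC(C)=CCCC1=CCc2c(O)ccc(O)c2C1` gives 4900 nM
Compound 2 `CC(=O)Oc1ccc(OC(C)=O)c2c1CC=C(CCC=C(C)C)C2` gives 3600 nM

Within the data shown here, in a functional assay on HT-29 cells (Homo sapiens) for cytotoxicity (on this read-out lower numbers stand for stronger inhibition and higher numbers for weaker inhibition), compound 1 (4900 nM) and compound 2 (3600 nM) lie within the usual scatter of each other, so neither ranks ahead of the other and compound 1 has no clear place above or below its only neighbour. Compound 3 (`CC(C)=CCCC1=CCc2c(O)cc(C)c(O)c2C1`) keeps the core of compound 1 and differs by methyl in place of hydrogen on an aromatic carbon, ortho to a hydroxy group. Among the measured compounds shown here, no measured step shows what such a change does in this assay here, so no step beyond the scatter is expected, in either direction. The expected size of the change is a 1.2-fold lower number from compound 1 to compound 3 (0.09 log units; within the scatter) and it remains only an estimate. For compound 3 the estimated value is 4000 nM (expected range 1800 nM to 9000 nM).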

Compound 3, half-maximal inhibitory concentration: 19400 nM
Beside the measured number, compound 3's estimate is 4.9-fold (0.69 log units) below it; the measured number lies above the stated range.
By their numbers in this assay, from the lowest: compounds 2 and 1 (each within the scatter of the next); then compound 3.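

In this assay the methyl in place of hydrogen on an aromatic carbon, ortho to a hydroxy group, proves not to be a neutral change: it gives a 4.0-fold higher number from compound 1 to compound 3 (0.60 log units; beyond the scatter) and is the first step beyond the scatter among these compounds. This aromatic position on the core of compound 1 therefore responds to a methyl, and it does so in the direction of weaker inhibition. Nothing measured here explains the step.

The compounds shown leave open whether this weakening is specific to methyl or would also follow from a chlorine, a methoxy group or a longer chain such as ethyl at the same position. They also leave open whether the same methyl would have a similar effect with both hydroxy groups carried as acetoxy groups, as in compound 2.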